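The compounds below may be only part of what the source reports. "The series", "measured", "known", "first", "only" and "open" are said of these compounds alone.

Of the compounds shown here, two have been measured so far in a functional assay on SF-268 cells (Homo sapiens) for inhibition, read by sulforhodamine B assay, with a stated time of 48 h; a lower number here means a stronger inhibitor of growth, a higher number a weaker inhibitor of growth. Compound 1 `CCOC(=O)[C@H](CCC(=O)O)NC(=O)c1ccc(Sc2nc3cc(N)cc(N)c3nc2-c2ccccc2)cc1` gives 44700 nM in this assay. Compound 2 `Nc1cc(N)c2nc(-c3ccccc3)c(Oc3ccc(F)cc3)nc2c1` gives 47900 nM in this assay. Compound 2 holds the higher of the two numbers, but its gap to compound 1 lies within the usual scatter of such measurements, so the two cannot be told apart; both are weak inhibitors of growth here, and compound 1 and compound 2 differ from each other in several places, so neither measurement explains the other.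

Compound 3 `Nc1cc(N)c2nc(-c3ccccc3)c(NCc3ccc(F)cc3)nc2c1` is the one still to be measured. It differs from compound 2 in a single place: (4-fluorobenzyl)amino in place of 4-fluorophenoxy on an aromatic carbon. Going by the values given here, no measured pair here shows what this kind of exchange does to the number, so the estimate rests on the near-equality of compound 1 and compound 2 alone. The expected step is a 1.1-fold lower number from compound 2 to compound 3 (0.06 log units; within the scatter), no larger than the scatter and with no direction favoured. For compound 3 the expected value in this assay is 42000 nM, with a range from 12000 nM to 150000 nM.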

Compound 3, concentration for total growth inhibition: 7590 nM
Beside the measured number, compound 3's estimate is 5.5-fold (0.74 log units) above it; the whole stated range lies above it.
By their numbers in this assay, from the lowest: compound 3; then compounds 1 and 2 (each within the scatter of the next).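

In this assay, the group at this position, on an aromatic carbon next to the ring nitrogen, clearly affects the number: replacing 4-fluorophenoxy with (4-fluorobenzyl)amino gives a 6.3-fold lower number from compound 2 to compound 3 (0.80 log units; beyond the scatter) and a stronger inhibitor of growth. Going by these compounds alone, this is the first single-place change in the set, and the first sign that the near-equal numbers of the two earlier compounds do not mean that the series is unresponsive to change. The exchange alters more than one feature at once, however: both groups hold one six-membered aromatic ring of carbon only, but the entering group has a nitrogen link, 1 hydrogen-bond donor rather than 0, and 9 heavy atoms rather than 8, and no measurement here accounts for the change in the number.

A 4-fluorobenzyloxy group would keep the oxygen link alongside the longer connection, while a (4-fluorophenyl)amino group would keep the nitrogen link without the added carbon, so either could help separate these two parts of the change. A simple benzylamino group, without the fluorine, would test whether that atom matters at this position.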